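The source may report more compounds than this note shows. Statements on the series, on what has been measured and on what is new or still open speak of the compounds shown alone.

In a functional assay on CHO-K1 cells for antagonist activity at transient receptor potential cation channel subfamily V member 1 (Homo sapiens), read by FLIPR (a lower number here means a stronger inhibitor, a higher number a weaker inhibitor), three compounds have been measured. Compound 1 `CC1CCC(Nc2nc(C(F)(F)F)ccc2CNC(=O)C(C)c2ccc(NS(C)(=O)=O)c(F)c2)CC1` gives 1130 nM. Compound 2 `CC(C(=O)NCc1ccc(C(F)(F)F)nc1N1CCCC1)c1ccc(NS(C)(=O)=O)c(F)c1` gives 211 nM, which is a 5.4-fold lower number from compound 1 to compound 2 (0.73 log units; beyond the scatter). Compound 3 `CC(C(=O)NCc1ccc(C(F)(F)F)nc1N1CCC(c2ccccc2)CC1)c1ccc(NS(C)(=O)=O)c(F)c1` gives 25 nM, the lowest of the three numbers; its nearest neighbour is compound 2, the step being an 8.4-fold lower number from compound 2 to compound 3 (0.93 log units; beyond the scatter), and the furthest is compound 1, the step being a 45-fold lower number from compound 1 to compound 3 (1.66 log units; beyond the scatter).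

Compound 4 `CC(C(=O)NCc1ccc(C(F)(F)F)nc1N1CCC(C(F)(F)F)CC1)c1ccc(NS(C)(=O)=O)c(F)c1` differs from compound 3 in one place: trifluoromethyl in place of phenyl on a saturated ring carbon. Going by the values given here, no measured step covers this exchange directly. The step that bears on it most is an 8.4-fold lower number from compound 2 to compound 3 (0.93 log units; beyond the scatter), in which the phenyl-bearing piperidine replaced a smaller ring without a pendant group; taking the phenyl away again, with a trifluoromethyl put in its place, is expected to give back part of that step, so that a modest rise in the number is expected for compound 4, short of the gap to compound 2. Compound 4 is therefore estimated at 80 nM in this assay, with a range from 25 nM to 250 nM, corresponding to an expected step of a 3.2-fold higher number from compound 3 to compound 4 (0.51 log units; beyond the scatter).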

Compound 4, half-maximal inhibitory concentration: 31 nM
Beside the measured number, compound 4's estimate is 2.6-fold (0.41 log units) above it; the range from low to high includes it.
By their numbers in this assay, from the lowest: compounds 3 and 4 (each within the scatter of the next); then compound 2; then compound 1.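

In this assay, putting trifluoromethyl in place of phenyl on this saturated ring carbon leaves the number within the scatter (a 1.2-fold higher number from compound 3 to compound 4 (0.09 log units; within the scatter)), so the pendant aromatic ring of the 4-phenylpiperidin-1-yl group is not needed to keep the number low in this series. A group with no ring and fewer heavy atoms retains the gain over the other two amine groups (a 6.8-fold lower number from compound 2 to compound 4 (0.83 log units; beyond the scatter); a 36-fold lower number from compound 1 to compound 4 (1.56 log units; beyond the scatter)). No evidence here speaks to the cause of this result.

The compounds shown leave open whether an unsubstituted piperidin-1-yl group would give a similarly low number, or whether methyl, hydroxyl or an amine on the same ring carbon would do so. They also do not separate the effect of ring size from that of the pendant group in the step away from pyrrolidin-1-yl.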